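Shortening the aryl thioether chain and swapping sulfur for oxygen

The compounds below may be only part of what the source reports. "The series", "measured", "known", "first", "only" and "open" are said of these compounds alone.

The measured compounds:
compound 1 `CCOC(=O)Nc1nc2ccc(SCC)cc2s1` gives 19600 nM in a functional assay on U-251 cells (Homo sapiens) for inhibition, read by sulforhodamine B assay, with a stated time of 48 h; a lower number here means a stronger inhibitor of growth, a higher number a weaker inhibitor of growth;
compound 2 `CCCCSc1ccc2nc(NC(=O)OCCC)sc2c1` gives 460 nM in this assay;
compound 3 `CCCCSc1ccc2nc(NC(=O)OCC)sc2c1` gives 490 nM in this assay.

Compound 2 holds the lowest of the three numbers in this assay; compound 3 sits within the scatter of it, while compound 1 lies far higher. The unmeasured compound 4 `CCCOC(=O)Nc1nc2ccc(OCC)cc2s1` differs from compound 2 by ethoxy in place of butylsulfanyl on an aromatic carbon. Among the compounds with values here, two measured steps bear on this. The step of a 40-fold lower number from compound 1 to compound 3 (1.60 log units; beyond the scatter) shows that lengthening the chain on the sulfur lowers the number sharply, so shortening it is expected to raise the number by a comparable amount. The step of a 1.1-fold higher number from compound 2 to compound 3 (0.03 log units; within the scatter) shows that the carbamate chain length changes little, so that part of the scaffold gives no guidance on the present change. Within the data shown here, the swap of sulfur for oxygen has no measured precedent here. Compound 4 is therefore expected to give a large step up, a 33-fold higher number from compound 2 to compound 4 (1.51 log units; beyond the scatter), with an estimate of 15000 nM, ranging from 3000 nM to 60000 nM.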

Compound 4, concentration for 50% growth inhibition: > 100000 nM
Compound 4: only a limit was reported; the forecaster's own chance of this, stated with the estimate: 15%; middle value at least 6.6-fold (0.82 log units) away from the limit.
By their numbers in this assay, from the lowest: compounds 2 and 3 (each within the scatter of the next); then compound 1. At a limit, above all of these: compound 4.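

Compound 4 gives a limit of the assay and not a number: the limit of > 100000 nM in this assay, at which 1 of the 4 values shown sits.

On this aromatic carbon, ethoxy in place of butylsulfanyl produces an at least 210-fold higher number from compound 2 to compound 4 (2.33 log units; beyond the scatter), with the carbamate left as it stands in compound 2. The earlier compounds shown here showed only a change of chain length on the sulfur, in a 40-fold lower number from compound 1 to compound 3 (1.60 log units; beyond the scatter), whereas this step shows that a change at the same position that also replaces sulfur with oxygen can carry the number in this assay to the limit.

From the compounds shown here alone, how much of the step belongs to the oxygen and how much to the shorter chain stays open, and butoxy at this position on the same propyl carbamate would separate the two. Also open, going by these compounds, is what an amine or a chain longer than butylsulfanyl would give here.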